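The source may hold more compounds than are shown below. What is called first, only, known or untested is meant among the compounds shown, and "the series" means these compounds.

Measured compounds: compound 1 `Cc1nn(CC(=O)N2CCN(c3sc(C(F)(F)F)nc3-c3nc4ccccc4[nH]3)C[C@H]2C)cc1CN(C)C` gives 2.7 nM in a functional assay on CHO-K1 cells for antagonist activity at C-X-C chemokine receptor type 3 (Homo sapiens), read by FLIPR, with a stated time of 10 min, in the presence of a further agent that is not named here; on this read-out lower numbers stand for stronger inhibition and higher numbers for weaker inhibition; compound 2 `C[C@@H]1CN(c2sc(C(F)(F)F)nc2-c2nc3ccccc3[nH]2)CCN1C(=O)Cn1cccn1` gives 13 nM; compound 3 `C[C@@H]1CN(c2sc(C(F)(F)F)nc2-c2nc3ccccc3[nH]2)CCN1C(=O)Cn1cnc2c1CCN(C)C2` gives 3.6 nM.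

Compound 2 stands at the highest of the three numbers: a 3.6-fold lower number from compound 2 to compound 3 (0.56 log units; beyond the scatter) separates it from compound 3, and a 4.8-fold higher number from compound 1 to compound 2 (0.68 log units; beyond the scatter) separates it from compound 1. Compound 4 `C[C@@H]1CN(c2sc(C(F)(F)F)nc2-c2nc3ccccc3n2C)CCN1C(=O)Cn1cccn1` differs from compound 2 by methyl in place of hydrogen on an aromatic nitrogen. For the measured compounds named here, none of the measured steps touches this position; all three vary the group on the saturated chain carbon bound to the carbonyl carbon, so they offer no guide to the size or direction of this change. The expectation for compound 4 rests on compound 2 alone and is expected to be a small step, a 2.3-fold higher number from compound 2 to compound 4 (0.36 log units; beyond the scatter), with a wide range. Compound 4 is estimated at 30 nM, between 6 nM and 150 nM.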

Compound 4, half-maximal inhibitory concentration: 110 nM
The estimate for compound 4 lay 3.7-fold (0.56 log units) below the measured number, and the stated range covers the measured number.
By their numbers in this assay, from the lowest: compounds 1 and 3 (each within the scatter of the next); then compound 2; then compound 4.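

Methyl in place of hydrogen on the aromatic nitrogen, turning 1H-benzimidazol-2-yl into 1-methyl-1H-benzimidazol-2-yl, gives an 8.5-fold higher number from compound 2 to compound 4 (0.93 log units; beyond the scatter). This first reading at this position shows that one added carbon on that nitrogen weakens inhibition, and by more than the change on the saturated chain carbon gives in a 4.8-fold higher number from compound 1 to compound 2 (0.68 log units; beyond the scatter). Nothing measured here accounts for the loss.

From the compounds shown here alone, it remains open whether the hydrogen itself matters or only the added methyl, and how an ethyl group or a longer chain on that nitrogen would read. Also open, going by these compounds, is whether the same methyl would weaken compound 1 or compound 3 to a similar degree.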